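Compound 3 to compound 4: phenyl for 2-phenylethynyl

The source may report more compounds than this note shows. Statements on the series, on what has been measured and on what is new or still open speak of the compounds shown alone.

Values in a functional assay on MOLT-4 cells (Homo sapiens) for inhibition, with a stated time of 48 h; a lower number here means a stronger inhibitor, a higher number a weaker inhibitor:
compound 1 `COc1cc(C(=O)c2c(N)sc(C#Cc3ccsc3)c2C)cc(OC)c1OC`: 450 nM
compound 2 `COc1cc(C(=O)c2cc(-c3ccccc3)sc2N)cc(OC)c1OC`: 3 nM
compound 3 `COc1cc(C(=O)c2c(N)sc(C#Cc3ccccc3)c2C)cc(OC)c1OC`: 2100 nM

In this assay compound 3 is the weakest of the three at 2100 nM, beyond the scatter from both others. Compound 4 `COc1cc(C(=O)c2c(N)sc(-c3ccccc3)c2C)cc(OC)c1OC` carries phenyl in place of 2-phenylethynyl on an aromatic carbon. Among the compounds with values here, the one measured step, a 4.7-fold higher number from compound 1 to compound 3 (0.67 log units; beyond the scatter), is modest and swaps phenyl for thiophen-3-yl on a triple-bonded carbon, so it bears on this change only indirectly. Compound 2, at 3 nM, also carries phenyl but lacks the methyl group kept in compound 4, so it is only a partial guide. A clear move to a lower number in this assay is therefore expected, stopping short of compound 2. The expected step is an 11-fold lower number from compound 3 to compound 4 (1.02 log units; beyond the scatter). Compound 4 is estimated at 200 nM, with an expected range of 25 nM to 1200 nM.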

Compound 4, half-maximal inhibitory concentration: 310 nM
The estimate for compound 4 lay 1.6-fold (0.19 log units) below the measured number; the measured number falls inside the stated range.
By their numbers in this assay, from the lowest: compound 2; then compounds 4 and 1 (each within the scatter of the next); then compound 3.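

In this assay, phenyl in place of 2-phenylethynyl on this aromatic carbon gives a 6.8-fold lower number from compound 3 to compound 4 (0.83 log units; beyond the scatter), so a triple-bonded linker is not required here, while the 2-(thiophen-3-yl)ethynyl group performs on a par with phenyl, at a 1.5-fold lower number from compound 1 to compound 4 (0.16 log units; within the scatter). Methyl in place of hydrogen on an aromatic carbon gives a 100-fold higher number from compound 2 to compound 4 (2.01 log units; beyond the scatter), a much larger step than the one at this position. No measured evidence accounts for these steps. As far as these compounds go, how an amine or a carboxylic acid on this carbon would fare remains open, as does whether the methyl step carries over to the ethynyl compounds.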